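A few compounds are considered here, and "the series" means these few. Any claim that something is new, unique, unknown or untested is made for them only; others in the source may bear on it.

Working notes on a small set built on a shared core, read in a physicochemical assay for solubility, with a stated time of 18 h, at pH 7.4; a lower number here means a less soluble compound, a higher number a more soluble compound.

Compound 2 `COc1cccc(CNCCCNc2ccnc3cc(CC(C)C)ccc23)c1O` gives 4200 nM in this assay. Compound 1 `COc1cccc(CNCCCNc2ccnc3cc(Oc4ccccc4)ccc23)c1O` differs from it by phenoxy in place of isobutyl on an aromatic carbon; in this assay compound 1 gives 14500 nM, and the step is a 3.5-fold higher number from compound 2 to compound 1 (0.54 log units; beyond the scatter).

Compound 3 `COc1ccc(F)cc1CNCCCNc1ccnc2cc(CC(C)C)ccc12` differs from compound 2 by 5-fluoro-2-methoxyphenyl in place of 2-hydroxy-3-methoxyphenyl on a saturated chain carbon bound to an amine nitrogen. In this assay compound 3 gives 4200 nM, the step being no change at the digits printed from compound 2 to compound 3 (within the scatter). Compound 3 and compound 2 therefore stand together, both lower than compound 1 by the step already noted.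

Compound 4 `COc1ccc(F)cc1CNCCCNc1ccnc2cc(Oc3ccccc3)ccc12` has not yet been measured. It differs from compound 3 by phenoxy in place of isobutyl on an aromatic carbon. This is the same change as that made from compound 2 to compound 1, at the same place, and it occurs twice among the four compounds. Within the data shown here, only the one measured instance of it is available as a guide, and the cores on which it acts differ by the change set out above.

From compound 3 to compound 4 the step in this assay is expected to be a 3.5-fold higher number from compound 3 to compound 4 (0.54 log units; beyond the scatter), beside the earlier 3.5-fold higher number from compound 2 to compound 1 (0.54 log units; beyond the scatter). This expectation rests on that single measured step and on the starting point of compound 3, which gives 4200 nM in this assay. The estimate for compound 4 in this assay is 14500 nM, expected to fall between 7000 nM and 30000 nM.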

Compound 4, solubility: 14500 nM
For compound 4 middle estimate and measured number coincide at the digits printed; the measured number falls inside the stated range.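

In this assay, phenoxy in place of isobutyl on an aromatic carbon gives a 3.5-fold higher number from compound 3 to compound 4 (0.54 log units; beyond the scatter) on the core of compound 3, and this matches a 3.5-fold higher number from compound 2 to compound 1 (0.54 log units; beyond the scatter) on the core of compound 2, so the change carries across these two cores with no difference at the digits printed. The other change in the set agrees with this reading: 5-fluoro-2-methoxyphenyl in place of 2-hydroxy-3-methoxyphenyl gives no change at the digits printed from compound 1 to compound 4 (within the scatter) with phenoxy present, and no change at the digits printed from compound 2 to compound 3 (within the scatter) with isobutyl present, so within these four compounds the two changes act as if independent of each other. Among these compounds, this rests on only two pairs and two cores, so it shows no general rule for the series, and nothing available bears on what lies behind either step.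

The compounds shown leave open whether the same step would appear on a third core, for instance one whose benzyl ring carries a nitrile in place of the fluoro and methoxy groups. They also leave open how an amine, a carboxylic acid or a longer alkyl chain would read in this assay on the aromatic carbon that holds isobutyl or phenoxy here.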